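Swapping the aryl ketone for a cyclopropyl ketone

The compounds below may be only part of what the source reports. "The series", "measured", "known", "first", "only" and "open" are said of these compounds alone.

Compound 1 `COc1cc(-c2nnc3n2NC(c2ccco2)C(C(=O)c2ccccc2C)S3)cc(OC)c1OC`: 80000 nM
Compound 2 `COc1cc(-c2nnc3n2NC(c2ccco2)C(C(=O)c2cccs2)S3)cc(OC)c1OC`: 78700 nM
Compound 3 `COc1cc(-c2nnc3n2NC(c2ccco2)C(C(=O)c2ccc(Cl)cc2)S3)cc(OC)c1OC`: 51400 nM

These three values all come from a functional assay on A549 cells (Homo sapiens) for cytotoxicity, read by MTT assay, with a stated time of 48 h; on this read-out lower numbers stand for stronger inhibition and higher numbers for weaker inhibition. Compound 3 has the lowest of the three numbers, yet the steps of a 1.6-fold lower number from compound 1 to compound 3 (0.19 log units; within the scatter) and a 1.5-fold lower number from compound 2 to compound 3 (0.19 log units; within the scatter) are both within the scatter, as is a 1.0-fold lower number from compound 1 to compound 2 (0.01 log units; within the scatter). Compound 4 `COc1cc(-c2nnc3n2NC(c2ccco2)C(C(=O)C2CC2)S3)cc(OC)c1OC` differs from compound 3 by cyclopropyl in place of 4-chlorophenyl on a carbonyl carbon. Every step seen so far changed the group on that same carbonyl carbon and left the read-out essentially unchanged, so no step beyond the scatter is expected here either. Compound 4 is therefore estimated at 70000 nM, with a range of 30000 nM to 160000 nM. This estimate corresponds to an expected step of a 1.4-fold higher number from compound 3 to compound 4 (0.13 log units; within the scatter).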

Compound 4, half-maximal inhibitory concentration: > 100000 nM
Compound 4: no number, only a limit (the forecaster's own chance of this, stated with the estimate: 20%); middle value at least 1.4-fold (0.15 log units) away from the limit.
By their numbers in this assay, from the lowest: compounds 3, 2 and 1 (each within the scatter of the next). At a limit, above all of these: compound 4.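

Compound 4, the only one shown with a non-aromatic ring on this carbonyl carbon, gives > 100000 nM in this assay, which is a limit of the assay and not a number. The steps of an at least 1.9-fold higher number from compound 3 to compound 4 (0.28 log units; that floor lies within the scatter), an at least 1.2-fold higher number from compound 2 to compound 4 (0.10 log units; that floor lies within the scatter) and an at least 1.2-fold higher number from compound 1 to compound 4 (0.09 log units; that floor lies within the scatter) are floors only, and each floor lies within the scatter, so this change cannot yet be told apart from the earlier swaps. What is new is that a change at this position now reaches a limit: the limit of > 100000 nM in this assay, at which 1 of the 4 values shown sits.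

From the compounds shown here alone, how an amine or a carboxylic acid would read on this carbonyl carbon stays open. So does whether changes elsewhere on the shared core would move the read-out at all.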